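The compounds below may be only part of what the source reports. "The series", "measured", "known", "first", "only" and "open" are said of these compounds alone.

The study concerns compound 1, `CCOC(=O)CCCC/C=C(\c1ccccc1)c1cccnc1`, in an assay (Equus caballus) for inhibition of Thromboxane-A synthase (Homo sapiens), using microsomes (on this read-out higher numbers stand for weaker inhibition and lower numbers for stronger inhibition), where compound 1 gives 600 nM. Among the three compounds measured in this assay, compound 1 has the highest number, and both other compounds lie beyond the scatter from it. Compound 2, `COc1ccc(/C(=C/CCCCC(=O)O)c2cccnc2)cc1`, gives 80 nM in this assay, and compound 3, `O=C(O)CCCC/C=C(/CCCc1ccccc1)c1cccnc1`, gives 65 nM. Among the compounds with values here, both compounds 2 and 3 carry a free carboxylic acid at the end of their chain, while compound 1 carries an ethyl ester there; no single-point step between any two of the measured compounds is available, so these values are only set side by side.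

The step to compound 4, `O=C(O)CCC/C=C(\c1ccccc1)c1cccnc1`, changes compound 1 in one place: carboxy in place of (ethoxycarbonyl)methyl on a saturated chain carbon, three bonds along the chain from a double-bonded chain carbon. Compound 4 thus joins compounds 2 and 3 in bearing a free carboxy group on its chain. Since compound 2 gives 80 nM and compound 3 gives 65 nM in this assay, while compound 1 with its ester gives 600 nM, the expected direction for compound 4 is toward stronger inhibition, with a step of a 6.0-fold lower number from compound 1 to compound 4 (0.78 log units; beyond the scatter) expected, beyond the scatter. The estimate for compound 4 in this assay is 100 nM, expected to fall between 30 nM and 400 nM.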

Compound 4, half-maximal inhibitory concentration: 30 nM
For compound 4 the middle estimate is 3.3-fold (0.52 log units) above the measured one, and the stated range covers the measured number.
By their numbers in this assay, from the lowest: compound 4; then compounds 3 and 2 (each within the scatter of the next); then compound 1.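

The change of (ethoxycarbonyl)methyl to carboxy, on a saturated chain carbon, three bonds along the chain from a double-bonded chain carbon, gives in this assay a 20-fold lower number from compound 1 to compound 4 (1.30 log units; beyond the scatter), a large step. Within the data shown here, this is the first comparison in the set between two compounds that differ in one place, so the end of the chain at this position is now tied directly to a large difference in inhibition, rather than only through compounds set side by side; the change nonetheless replaces a group of 6 heavy atoms with one of 3, so the loss of the ester and the shortening of the chain arrive together. No measurement shown here explains why the number falls.

The pair leaves open how much of the step belongs to the free acid and how much to chain length, a question that the ethyl ester on the chain of compound 4 and the carboxylic acid on the longer chain of compound 1 would separate. As far as these compounds go, how a primary amide or a tetrazole at the same chain end would read in this assay also remains open.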